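The compounds below may be only part of what the source reports. "The series", "measured", "known", "first", "only" and "open" are said of these compounds alone.

Measured compounds in an ADME assay on BJ cells (Homo sapiens) for cytotoxicity, with a stated time of 72 h; on this read-out lower numbers stand for an effect already at smaller amounts and higher numbers for an effect only at larger amounts of compound:
Compound 1, `Cc1cc(NC(=O)Nc2ccccc2C(F)(F)F)c2ccccc2n1`, gives > 25000 nM, a limit of the assay.
Compound 2, `CC(=O)c1ccc(NC(=O)Nc2cc(C)nc3ccccc23)cc1`, gives 22000 nM.
Compound 3, `Cc1cc(NC(=O)Nc2ccc(Cl)cc2)c2ccccc2n1`, gives > 25000 nM, a limit of the assay.

Compound 1 therefore stands at the edge of what this assay reports: its number is a limit, not a measured value, and compound 3 sits at the same limit, as noted in the limit of > 25000 nM in this assay, at which 2 of the 3 values shown sit. Compound 2 alone gives a number, and the step of an at least 1.1-fold higher number from compound 2 to compound 3 (0.05 log units; that floor lies within the scatter) is within the scatter, so the three measured compounds cannot be told apart on this read-out.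

The unmeasured compound 4, `Cc1cc(NC(=O)Nc2ccccc2C(N)=O)c2ccccc2n1`, differs from compound 1 by carbamoyl in place of trifluoromethyl on an aromatic carbon. No measured step touches this group; the only step shown, an at least 1.1-fold higher number from compound 2 to compound 3 (0.05 log units; that floor lies within the scatter), concerns a different change and was itself within the scatter. Within the data shown here, nothing among the measured values suggests a shift beyond the scatter, so compound 4 is expected to remain near the limit, with an estimated step that the limit leaves unreadable from compound 1 to compound 4. Compound 4 is estimated at 30000 nM, within 12000 nM to 75000 nM.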

Compound 4, half-maximal effective concentration: > 25000 nM
Compound 4: only a limit was reported; the forecaster's own chance of this, stated with the estimate: 70%; the middle value is on the limit's open side.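

Compound 4 gives > 25000 nM, a limit of the assay. Compound 1 also sits at a limit, so no step between compound 1 and compound 4 can be read: the limit of > 25000 nM in this assay, at which 3 of the 4 values shown sit.

The compounds shown leave open whether carbamoyl in place of trifluoromethyl on an aromatic carbon changes the read-out at all.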